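Aryl-amide variation in a fluorophenyl dihydrofuran series

The source may hold more compounds than are shown below. What is called first, only, known or untested is meant among the compounds shown, and "the series" means these compounds.

Compound 1 `C=CC1=C(C(=O)Nc2ccc(C)cc2)C(c2ccc(F)cc2)OC1` is the reference for this step. Within the data shown here, in a functional assay on QGY7701 cells (Homo sapiens) for cytotoxicity, read by MTT assay, with a stated time of 24 h (on this read-out lower numbers stand for stronger inhibition and higher numbers for weaker inhibition), compound 1 gives 59200 nM, the lowest of the two numbers so far; compound 2 `C=CC1=C(C(=O)NCc2ccccc2)C(c2ccc(F)cc2)OC1` gives 67600 nM, and the step of a 1.1-fold higher number from compound 1 to compound 2 (0.06 log units; within the scatter) lies within the scatter. Compound 3 `C=CC1=C(C(=O)Nc2ccc(OCC)cc2)C(c2ccc(F)cc2)OC1` is not yet measured. Relative to compound 1 it carries ethoxy in place of methyl on an aromatic carbon. Among the measured compounds shown here, the only measured step, from compound 1 to compound 2, concerns the group on the amide nitrogen rather than a substituent on the aryl ring, so nothing measured speaks directly to the change made here; that step was within the scatter, and with no indication of any effect from varying this part of the molecule, no step beyond the scatter is expected for compound 3 in this assay. Compound 3 is therefore estimated at 55000 nM, range 25000 nM to 120000 nM, an expected step of a 1.1-fold lower number from compound 1 to compound 3 (0.03 log units; within the scatter).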

Compound 3, half-maximal inhibitory concentration: 61600 nM
Compound 3: middle estimate off by 1.1-fold (0.05 log units), on the low side; the measured number falls inside the stated range.
By their numbers in this assay, from the lowest: compounds 1, 3 and 2 (each within the scatter of the next).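

Ethoxy in place of methyl on an aromatic carbon, para to a large group, is the first change read on the aryl ring itself, and in this assay it gives a 1.0-fold higher number from compound 1 to compound 3 (0.02 log units; within the scatter). This place on the ring therefore takes the larger ethoxy group, with its oxygen, without a step beyond the scatter, a reading that holds for this one pair only. Nothing measured alongside these numbers accounts for the result.

As far as these compounds go, whether an amine, a carboxylic acid or a longer alkoxy chain at this place would give a step beyond the scatter stays open. Also open, from the compounds shown here alone, is what a chlorine or a nitrile would do in place of the fluorine of the fluorophenyl group.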